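This account rests on a few compounds, and the source may have more. Where it says the series, first, only, none or still open, it means among the compounds named here.

Of the compounds shown here, two of the same spiro-fused core have been measured in an assay on HEK293 cells for displacement of a labelled ligand from NPC1-like intracellular cholesterol transporter 1 (Homo sapiens); a lower number here means a stronger inhibitor, a higher number a weaker inhibitor. Compound 1, `CC(C)(C)OC(=O)NC1CCCN(C(=O)CN2CN(c3ccccc3)C3(CCN(C(=O)c4ccc(C5CCCCC5)cc4)CC3)C2=O)C1`, gives 4400 nM in this assay. Compound 2, `CC(C)(C)c1ccc(C(=O)N2CCC3(CC2)C(=O)N(CC(=O)N2CCCC(C(N)=O)C2)CN3c2ccccc2)cc1`, gives 16900 nM in this assay, the higher of the two numbers, and the gap between compound 1 and compound 2 lies beyond the scatter of repeated measurements. Compound 3, `CC(C)(C)c1ccc(C(=O)N2CCC3(CC2)C(=O)N(CC(=O)N2CCC(CCO)CC2)CN3c2ccccc2)cc1`, has not yet been measured. It differs from compound 2 in one place: 4-(2-hydroxyethyl)piperidin-1-yl in place of 3-carbamoylpiperidin-1-yl on a carbonyl carbon. Among the compounds with values here, no measured pair shows this exchange, so nothing in the data sets its size or direction. With one hydrogen-bond donor and one acceptor kept on each side, compound 3 is expected to move only a little from compound 2, with a step of a 1.4-fold lower number from compound 2 to compound 3 (0.15 log units; within the scatter) that need not exceed the scatter. Compound 3 is therefore estimated at 12000 nM in this assay, in the range 4000 nM to 36000 nM, because compound 2 gives 16900 nM.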

Compound 3, half-maximal inhibitory concentration: 2600 nM
Estimate against measurement, compound 3: 4.6-fold (0.66 log units) above; the measured number lies below the stated range.
By their numbers in this assay, from the lowest: compounds 3 and 1 (each within the scatter of the next); then compound 2.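

In this assay, within the data shown here, exchanging the 3-carbamoylpiperidin-1-yl group for the 4-(2-hydroxyethyl)piperidin-1-yl group gives a 6.5-fold lower number from compound 2 to compound 3 (0.81 log units; beyond the scatter) and provides the first sign that the group at this place can alter the number. The two groups have the same count of heavy atoms, hydrogen-bond donors and acceptors, and each carries one six-membered non-aromatic ring, yet the step lies beyond the scatter; these counts alone therefore do not settle the outcome at this position. No measurement shown accounts for the step.

The exchange alters both the side chain and where it stands in the group's name, and the compounds shown do not separate the two. Also open, from the compounds shown here alone, is whether the hydroxyl of the 2-hydroxyethyl chain matters, and what a longer chain, an amine or a carboxylic acid would give in its place.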